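A few compounds are considered here, and "the series" means these few. Any claim that something is new, unique, unknown or untested is made for them only; others in the source may bear on it.

Compound 1 has the structure `Cc1ccc(Nc2ncc(C(F)(F)F)c(N3Cc4cccc(N(C)S(C)(=O)=O)c4C3)n2)cc1C`. In a functional assay on OVCAR-3 cells (Homo sapiens) for antiproliferative activity, read by spectrophotometry, with a stated time of 2 days (a higher number here means a weaker inhibitor of growth, a lower number a stronger inhibitor of growth), compound 1 gives > 30000 nM, which is a limit of the assay rather than a measured number. Among the measured compounds shown here, its close relative compound 2, with the structure `Cc1cc(C)cc(Nc2ncc(C(F)(F)F)c(N3Cc4cccc(N(C)S(C)(=O)=O)c4C3)n2)c1`, is the only other measured compound here. In this assay compound 2 gives > 30000 nM, again a limit of the assay. The step between them, a step that the two limits leave unreadable from compound 1 to compound 2, therefore cannot be read in either direction or size, because of the limit of > 30000 nM in this assay, at which 2 of the 2 values shown sit. For the measured compounds named here, compound 1 thus stands at the limit, and no measured compound distinguishes itself from it.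

The next compound, compound 3, has the structure `CN(c1cccc2c1CN(c1nc(Nc3ccc(Cl)c(C(F)(F)F)c3)ncc1C(F)(F)F)C2)S(C)(=O)=O`. The change from compound 1 is 4-chloro-3-(trifluoromethyl)phenyl in place of 3,4-dimethylphenyl on a nitrogen on an aromatic ring. Going by the values given here, the one measured step, from compound 1 to compound 2, bears on the same position, but since both of its values are limits it gives no size and no direction to carry over. No step beyond the usual scatter can be expected with confidence, and the most likely outcome is that compound 3 also reaches only the limit. The estimate for compound 3 in this assay is 30000 nM, with a range from 8000 nM to 100000 nM, meaning an expected step of a number no higher from compound 1 to compound 3 (the limit leaves the size open).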

Compound 3, concentration for 50% growth inhibition: > 50000 nM
Compound 3 was reported as a limit; the forecaster's own chance of this, stated with the estimate: 60%; middle value at least 1.6-fold (0.22 log units) from the limit.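

In this assay compound 3 gives > 50000 nM, which is a limit of the assay. The steps to compound 3 from compound 1 and from compound 2 therefore cannot be read. The compounds shown leave open whether changing the substituted phenyl group on this nitrogen alters growth inhibition at all, and in which direction.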